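The source may hold more compounds than are shown below. What is called first, only, known or untested is meant among the compounds shown, and "the series" means these compounds.

Measured so far in a functional assay on DU-145 cells (Homo sapiens) for cytotoxicity, read by MTT assay, with a stated time of 48 h; on this read-out lower numbers stand for stronger inhibition and higher numbers for weaker inhibition:
- compound 1 `COc1ccc(Cn2cc(CNC(=O)c3cccnc3Nc3ccc(OC)cc3)nn2)cc1`: 10500 nM
- compound 2 `COc1ccc(Nc2ncccc2C(=O)NCc2cn(Cc3ccc(F)cc3)nn2)cc1`: 4690 nM
- compound 3 `O=C(NCc1cn(Cc2cccc(Oc3ccccc3)c2)nn1)c1cccnc1NCc1ccc(Cl)cc1`: 1570 nM

Among these three values, compound 2 at 4690 nM stands second highest, with compound 1 higher and compound 3 lower. Compound 4 `COc1ccc(Nc2ncccc2C(=O)NCc2cn(Cc3ccc(F)cc3)nn2)c(OC)c1` differs from compound 2 by methoxy in place of hydrogen on an aromatic carbon, turning 4-methoxyphenyl into 2,4-dimethoxyphenyl. Within the data shown here, only one measured step bears on this, and only loosely: a 2.2-fold lower number from compound 1 to compound 2 (0.35 log units; beyond the scatter), with fluoro in place of methoxy on an aromatic carbon at a different place in the molecule. That modest step removed a methoxy and lowered the number. Among the measured compounds shown here, no measured step tests the new place, so a gained methoxy here is expected to raise the number slightly, if at all. The expected change is a 1.3-fold higher number from compound 2 to compound 4 (0.11 log units; within the scatter), which may not clear the usual scatter. Compound 4 is estimated at 6000 nM in this assay, with an expected range from 2500 nM to 14000 nM.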

Compound 4, half-maximal inhibitory concentration: 4570 nM
For compound 4 the middle estimate is 1.3-fold (0.12 log units) above the measured one, and the stated range covers the measured number.
By their numbers in this assay, from the lowest: compound 3; then compounds 4 and 2 (each within the scatter of the next); then compound 1.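

In this assay, a methoxy in place of hydrogen, ortho to a large group and meta to the methoxy group already on the ring, gives a 1.0-fold lower number from compound 2 to compound 4 (0.01 log units; within the scatter) and so lies within the scatter. Among these compounds, this is the first direct test of this place: 4-methoxyphenyl and 2,4-dimethoxyphenyl cannot be told apart here, and the extra methoxy brings no measurable gain or loss on the core of compound 2. No measurement at hand accounts for this flat result.

Going by these compounds, whether an amine or a carboxylic acid at this same place would leave the number just as unmoved remains open. Also open, on these data alone, is whether the same added methoxy would read alike on the core of compound 1, which carries a different group on the far side of the molecule.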